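The source may report more compounds than this note shows. Statements on the series, on what has been measured and on what is new or still open speak of the compounds shown alone.

Measured in a functional assay on HeLa cells (Homo sapiens) for antiproliferative activity, read by MTT assay, with a stated time of 72 h; a lower number here means a stronger inhibitor, a higher number a weaker inhibitor:
- Compound 1 `O=C1COc2ccc(-c3cnc(Cl)c(NS(=O)(=O)c4ccc(F)cc4)c3)cc2N1C1CCCCC1`: 14300 nM
- Compound 2 `O=C1COc2ccc(-c3cccc(NS(=O)(=O)c4ccc(F)cc4)c3)cc2N1`: > 40000 nM (a limit of the assay, not a number)
- Compound 3 `O=C1COc2ccc(-c3cnc(Cl)c(NS(=O)(=O)c4ccc(F)cc4)c3)cc2N1`: 15600 nM

Compound 2 has no exact value. Its result, > 40000 nM, is a limit. It stands at the limit of > 40000 nM in this assay, at which 1 of the 3 values shown sits.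

Compound 4 `COc1cccc(N2C(=O)COc3ccc(-c4cccc(NS(=O)(=O)c5ccc(F)cc5)c4)cc32)c1`, not yet measured, is built from compound 2 by one change: 3-methoxyphenyl in place of hydrogen on an amide-type nitrogen in a ring. In words, 3-methoxyphenyl replaces hydrogen on an amide-type nitrogen in a ring.

For the measured compounds named here, only one measured step bears on that nitrogen. It is a 1.1-fold higher number from compound 1 to compound 3 (0.04 log units; within the scatter), with hydrogen in place of cyclohexyl, and it lies within the scatter. This evidence is thin. It is a single pair, its group is not 3-methoxyphenyl, and its core differs from that of compound 2. Still, it gives no sign that a substituent on this nitrogen moves the result in this assay, so no step beyond the scatter is expected, and no direction can be argued firmly.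

The expected step is a number no higher from compound 2 to compound 4 (the limit leaves the size open), and it is uncertain because compound 2 has only the limit of > 40000 nM as its starting point. The assay may well report only a limit again. For compound 4 the estimated value is 40000 nM, with an expected range from 15000 nM to 80000 nM.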

Compound 4, half-maximal inhibitory concentration: > 40000 nM
Compound 4: no number, only a limit; the forecaster's own chance of this, stated with the estimate: 55%; the middle value sits exactly at the limit.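

In this assay, compound 4 gives > 40000 nM, which is a limit of the assay and not a number. Compound 2 also has only a limit, so no step can be read between compound 2 and compound 4. The compounds shown leave open whether 3-methoxyphenyl in place of hydrogen on this amide-type nitrogen changes the result at all.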